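A Pyridine Swap on a Weak Fatty Acid Transport Inhibitor

The compounds below may be only part of what the source reports. "The series", "measured", "known", "first", "only" and "open" are said of these compounds alone.

Compound 1, `O=C(CN1CCN(C2CCCCC2)CC1)Nc1nc2c(s1)CCCC2`, gives in an assay on isolated protein for inhibition of long-chain fatty acid transport protein 1 (Mus musculus), read by scintillation counting, with a stated time of 20 min (on this read-out lower numbers stand for stronger inhibition and higher numbers for weaker inhibition), only a limit, > 10000 nM.
Compound 2, `O=C(CN1CCN(c2cccc(F)c2)CC1)Nc1nc2c(s1)CCCC2`, gives in this assay only a limit, > 10000 nM.
Compound 3, `O=C(CN1CCN(c2ccc(F)cc2)CC1)Nc1nc2c(o1)CCCC2`, gives in this assay a value of 5400 nM.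

Compound 2 stands at the edge of what this assay can report: its result is a limit, not a number. Compound 1 sits at the same limit, so the change from cyclohexyl to 3-fluorophenyl on the ring nitrogen gives a step that the two limits leave unreadable from compound 1 to compound 2. This follows from the limit of > 10000 nM in this assay, at which 2 of the 3 values shown sit, which caps two of the three values shown. Compound 3 differs from compound 2 in more than one place, so its value only shows that a close relative can be read as a number, though a weak one.

Compound 4, `O=C(CN1CCN(c2ccncc2)CC1)Nc1nc2c(s1)CCCC2`, carries pyridin-4-yl in place of 3-fluorophenyl on an amine nitrogen in a ring. For the measured compounds named here, no measured step follows this change, and the one step available, from compound 1 to compound 2, cannot be sized. There is therefore nothing to point to a direction, and the expectation is that compound 4 stays near the limit where compound 2 lies. The step from compound 2 to compound 4 is thus expected to be a number no higher from compound 2 to compound 4 (the limit leaves the size open). Compound 4 is estimated at 10000 nM, with a range from 3000 nM to 30000 nM.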

Compound 4, half-maximal inhibitory concentration: > 10000 nM
Compound 4: no number, only a limit (the forecaster's own chance of this, stated with the estimate: 60%); the middle value lies on the limit itself.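

Compound 4 gives only a limit and not a number, as do compound 1 and compound 2, so no step among these three compounds can be read: the limit of > 10000 nM in this assay, at which 3 of the 4 values shown sit. The compounds shown leave open whether pyridin-4-yl in place of 3-fluorophenyl on the amine nitrogen in a ring changes inhibition at all, and in which direction.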